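Fluorine in place of the amino group of compound 1

This account rests on a few compounds, and the source may have more. Where it says the series, first, only, none or still open, it means among the compounds named here.

Compound 1 `CCOC(=O)C(=O)Nc1cccc(N)c1C#N` is measured in a functional assay on the whole organism with Rattus norvegicus as the target (on this read-out higher numbers stand for an effect only at larger amounts of compound and lower numbers for an effect already at smaller amounts), at 0.07 mg/kg. Among the three measured compounds this is the second highest number. The nearest neighbour is compound 2 `CCNc1cccc(NC(=O)C(=O)OCC)c1C#N`, which in this assay gives 0.03 mg/kg; the step of a 2.3-fold lower number from compound 1 to compound 2 (0.37 log units; beyond the scatter) is modest. The furthest is compound 3 `CCOC(=O)C(=O)Nc1cccc(N(C)C(C)C)c1C#N`, which gives 1.2 mg/kg; the step of a 17-fold higher number from compound 1 to compound 3 (1.23 log units; beyond the scatter) is large, and the step of a 40-fold higher number from compound 2 to compound 3 (1.60 log units; beyond the scatter) is larger still.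

Compound 4 `CCOC(=O)C(=O)Nc1cccc(F)c1C#N` is not yet measured. Its difference from compound 1 is fluoro in place of amino on an aromatic carbon. All three measured steps alter the same position on the core of compound 1, but each keeps a nitrogen there: ethyl on that nitrogen lowered the number, while isopropyl(methyl)amino in place of amino or ethylamino raised it strongly. Among the compounds with values here, no measured step removes the nitrogen altogether, so the data give only a loose guide. On these data alone, the small amino gave a low number and the bulkiest amine the highest; fluoro is small, but unlike either amine it carries no hydrogen-bond donor or acceptor, and the direction of that loss is untested here. A moderate rise, a 4.3-fold higher number from compound 1 to compound 4 (0.63 log units; beyond the scatter), is therefore expected, with wide uncertainty. In this assay compound 4 is estimated at 0.3 mg/kg, in the range 0.07 mg/kg to 1.2 mg/kg.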

Compound 4, dose for half-maximal effect: 59 mg/kg
For compound 4 the middle estimate is 200-fold (2.29 log units) below the measured one; measured number above the stated range.
By their numbers in this assay, from the lowest: compound 2; then compound 1; then compound 3; then compound 4.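

In this assay this position turns out to depend far more on keeping a nitrogen than on what that nitrogen carries: an 840-fold higher number from compound 1 to compound 4 (2.93 log units; beyond the scatter) and a 2000-fold higher number from compound 2 to compound 4 (3.29 log units; beyond the scatter) both exceed every step among the three amines, and even the bulkiest amine stays well clear of fluoro, with a 49-fold higher number from compound 3 to compound 4 (1.69 log units; beyond the scatter). Size alone does not set the number here, since amino and fluoro each count 1 heavy atom and yet lie at opposite ends of the amino-to-fluoro step, while compound 3, with the largest group of the four, still falls short of compound 4. No measurement at hand accounts for why replacing the nitrogen with fluoro has so large an effect.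

The compounds shown leave open whether nitrogen as such is what matters, or whether a hydroxyl or a methoxy group at this position, with oxygen in place of the nitrogen, would keep the number close to that of compound 1. They also leave open how far substitution on the nitrogen can go between ethylamino and isopropyl(methyl)amino, for instance with a dimethylamino or a propylamino group, before the number climbs.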